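This account rests on a few compounds, and the source may have more. Where it says the series, first, only, none or still open, it means among the compounds named here.

Compound 1 `COc1ccc(/C=C/c2nc(NCCN(C(C)C)C(C)C)c3cc(Cl)ccc3n2)cc1OC` gives 15600 nM in a functional assay on MGC-803 cells (Homo sapiens) for cytotoxicity, read by MTT assay, with stated times of 48 h and 4 h; on this read-out lower numbers stand for stronger inhibition and higher numbers for weaker inhibition.
Compound 2 `COc1ccc(/C=C/c2nc(NCCN3CCCCC3)c3cc(Cl)ccc3n2)cc1OC` gives 13500 nM in this assay.
Compound 3 `CC(C)N(CCNc1nc(/C=C/c2ccc([N+](=O)[O-])cc2)nc2ccccc12)C(C)C` gives 29100 nM in this assay.

Compounds 1 and 2 share a core and differ in one place: piperidin-1-yl in place of diisopropylamino on a saturated chain carbon, two bonds along the chain from a nitrogen on an aromatic ring. That change made a 1.2-fold lower number from compound 1 to compound 2 (0.06 log units; within the scatter), so the two numbers sit within the scatter of each other and no order between them can be claimed. Compound 3 has a different core; the difference between the two cores is not broken down here. Its number in this assay is the highest of the three, within the scatter of compound 1 and beyond it against compound 2.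

Compound 4 `O=[N+]([O-])c1ccc(/C=C/c2nc(NCCN3CCCCC3)c3ccccc3n2)cc1` stands to compound 3 as compound 2 stands to compound 1: piperidin-1-yl in place of diisopropylamino on a saturated chain carbon, two bonds along the chain from a nitrogen on an aromatic ring. This is the same change, made at the same place, on the other core. Since the step from compound 1 to compound 2 was a 1.2-fold lower number from compound 1 to compound 2 (0.06 log units; within the scatter), compound 4 is expected to stay close to compound 3, with a step of about a 1.2-fold lower number from compound 3 to compound 4 (0.08 log units; within the scatter), resting on that single earlier step alone. The estimate for compound 4 in this assay is 24000 nM, between 10000 nM and 60000 nM.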

Compound 4, half-maximal inhibitory concentration: 27600 nM
Beside the measured number, compound 4's estimate is 1.2-fold (0.06 log units) below it; the measured number falls inside the stated range.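

In this assay, putting piperidin-1-yl in place of diisopropylamino on the core of compound 3 gave a 1.1-fold lower number from compound 3 to compound 4 (0.02 log units; within the scatter), so no order between these two compounds can be claimed. The same change on the two cores gave steps that agree: the same change on two cores in this assay, a 1.2-fold lower number (0.06 log units; within the scatter) from compound 1 to compound 2 and a 1.1-fold lower number (0.02 log units; within the scatter) from compound 3 to compound 4, 1.1-fold (0.04 log units) apart, within the scatter of two such steps. This shows that, on these two cores, the swap leaves the number within the scatter both times and that the core made no difference that can be seen here, but it rests on one pair per core and, with both steps so small, does not show that a larger effect would carry over from one core to the other, or that the same would hold on a third core.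

The compounds shown leave open whether another amine at the same place, such as morpholin-4-yl or dimethylamino, would move the number beyond the scatter on either core. They also leave open what a longer chain in place of the 2-(piperidin-1-yl)ethyl would do.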